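This account rests on a few compounds, and the source may have more. Where it says the series, first, only, none or still open, it means among the compounds named here.

Measured compounds:
- compound 1, `CC(=O)OC[C@H]1O[C@@H](n2cc(-c3cn(Cc4ccc(C(C)(C)C)cc4)nn3)c(=O)[nH]c2=O)C[C@@H]1OC(C)=O`: 94.2%
- compound 2, `O=c1[nH]c(=O)n([C@H]2C[C@H](O)[C@@H](CO)O2)cc1-c1cn(Cc2ccccc2)nn1`: 88.3%
- compound 3, `CCCCCc1cc(-c2cn([C@H]3C[C@H](OC(C)=O)[C@@H](COC(C)=O)O3)c(=O)[nH]c2=O)on1`: 98.7%

In a functional assay on HCT-15 cells (Homo sapiens) for cytotoxicity, read by sulforhodamine B assay, tested at 10 uM (on this read-out higher numbers stand for more inhibition at the one concentration tested (going by the name of the read-out) and lower numbers for less inhibition), compound 3 gives the highest of the three numbers. Compound 1 comes nearest, and its gap to compound 3 lies within the usual scatter, so the two cannot be ranked against each other. Compound 2 sits furthest away, and that gap is beyond the scatter.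

Compound 4, `CC(=O)OC[C@H]1O[C@@H](n2cc(-c3cc(-c4ccccc4)no3)c(=O)[nH]c2=O)C[C@@H]1OC(C)=O`, is not yet measured. It is compound 3 with one change: phenyl in place of pentyl on an aromatic carbon. For the measured compounds named here, no measured pair shows this change, so the expected size of the step is read from how close all three numbers already stand. The step of a number 6.7 percentage points lower from compound 3 to compound 4 (within the scatter) is expected to be small, downward if anything, and within the scatter. Compound 4 is therefore estimated at 92%, with a range from 78% to 100%.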

Compound 4, a percentage reported as inhibition, at one concentration (the size of the read-out at that concentration, not a potency): 92.2%
Estimate against measurement, compound 4: 0.2 percentage points below, within the range that was stated.
By their numbers in this assay, from the lowest: compounds 2, 4, 1 and 3 (each within the scatter of the next, the first and the last beyond it).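

In this assay, phenyl in place of pentyl on the aromatic carbon next to the ring nitrogen gives a number 6.5 percentage points lower from compound 3 to compound 4 (within the scatter). At this position, then, an aromatic ring and an open chain cannot be told apart on this read-out. No supporting measurement offers an explanation for this result. 

On these data alone, it remains open how an amine, a carboxylic acid or a chain longer than pentyl would fare at this position. A reading at a single concentration also leaves open how potency compares between these two compounds.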